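The source may hold more compounds than are shown below. What is called first, only, known or untested is meant among the compounds shown, and "the series" means these compounds.

Measured compounds:
compound 1 `CC(C)(C)c1ccc(-c2ccc3c(NCCCNCc4ccco4)ccnc3c2)cc1`, 237 10^-6 cm/s
compound 2 `CCC(CC)c1ccc2c(NCCCNCc3ccco3)ccnc2c1`, 23 10^-6 cm/s
compound 3 `c1coc(CNCCCNc2ccnc3cc(CC4CCCCC4)ccc23)c1`, 23 10^-6 cm/s

In an ADME assay for permeability, using PAMPA, with a stated time of 30 min, at pH 7.4 (on this read-out higher numbers stand for higher permeability and lower numbers for lower permeability), compound 1 gives the highest of the three numbers: the step of a 10-fold lower number from compound 1 to compound 2 (1.01 log units; beyond the scatter) and the step of a 10-fold lower number from compound 1 to compound 3 (1.01 log units; beyond the scatter) both fall away from it by large amounts, while the step of no change at the digits printed from compound 2 to compound 3 (within the scatter) stays within the scatter. Compound 4 `COc1ccc(F)cc1CNCCCNc1ccnc2cc(-c3ccc(C(C)(C)C)cc3)ccc12` is reached from compound 1 by 5-fluoro-2-methoxyphenyl in place of furan-2-yl on a saturated chain carbon bound to an amine nitrogen. Going by the values given here, no measured step touches that place; all three measured steps alter the group on an aromatic carbon of the shared core, so they give no direct guide to this change. With nothing in the data pointing either way, the expected step is a 1.2-fold lower number from compound 1 to compound 4 (0.07 log units; within the scatter), none beyond the scatter. Compound 4 is therefore estimated at 200 10^-6 cm/s, with a range from 90 10^-6 cm/s to 450 10^-6 cm/s.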

Compound 4, apparent permeability: 237 10^-6 cm/s
Estimate against measurement, compound 4: 1.2-fold (0.07 log units) below, and the stated range covers the measured number.
By their numbers in this assay, from the lowest: compounds 2 and 3 (each within the scatter of the next); then compounds 1 and 4 (each within the scatter of the next).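

In this assay, replacing furan-2-yl with 5-fluoro-2-methoxyphenyl gives no change at the digits printed from compound 1 to compound 4 (within the scatter). Going by these compounds alone, this is the first reading at this place, on a saturated chain carbon bound to an amine nitrogen, and it shows that a six-membered aromatic ring of 9 heavy atoms can stand where a five-membered one of 5 stood without moving the number beyond the scatter. No measured evidence here explains this result. Still open, on these data alone, is whether an unsubstituted phenyl or a saturated cyclohexyl ring would do the same here. Also open, as far as these compounds go, is whether this change would hold with pentan-3-yl on the core, as in compound 2.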